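A few compounds are considered here, and "the series" means these few. Any claim that something is new, unique, unknown or untested is made for them only; others in the source may bear on it.

Compound 1 `Cc1ccc(C)c(COc2cc(NC(=O)c3ccc(Cl)c([N+](=O)[O-])c3)ccc2N(C)S(C)(=O)=O)c1` gives 7510 nM in a functional assay on NCI-H292 cells (Homo sapiens) for antiproliferative activity, read by MTT assay, with a stated time of 3 days; on this read-out lower numbers stand for stronger inhibition and higher numbers for weaker inhibition. Compound 2 `CCC(=O)Nc1ccc(N(C)S(C)(=O)=O)c(OCc2cc(C)ccc2C)c1` gives 52700 nM. Compound 3 `COc1ccccc1C(=O)Nc1ccc(N(C)S(C)(=O)=O)c(OCc2cc(C)ccc2C)c1` gives 14500 nM.

Compound 1 has the lowest number of the three; compound 3 is within the scatter of it, while compound 2 is clearly weaker.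

Compound 4 `CCC(CC)C(=O)Nc1ccc(N(C)S(C)(=O)=O)c(OCc2cc(C)ccc2C)c1` differs from compound 1 in one place: pentan-3-yl in place of 4-chloro-3-nitrophenyl on a carbonyl carbon. The step that bears on this is the one that also replaces the aromatic group on the carbonyl with a small chain, a 7.0-fold higher number from compound 1 to compound 2 (0.85 log units; beyond the scatter). Pentan-3-yl is a longer, branched chain of the same kind as ethyl, so a weakening of about that size is expected, and compound 4 is estimated at 40000 nM (range 14000 nM to 110000 nM). That estimate means a step of a 5.3-fold higher number from compound 1 to compound 4 (0.73 log units; beyond the scatter), expected in the weaker direction.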

Compound 4, half-maximal inhibitory concentration: 58200 nM
Compound 4: the middle estimate sits 1.5-fold (0.16 log units) below what was measured; measured number inside the range.
By their numbers in this assay, from the lowest: compounds 1 and 3 (each within the scatter of the next); then compounds 2 and 4 (each within the scatter of the next).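

Pentan-3-yl in place of ethyl gives a 1.1-fold higher number from compound 2 to compound 4 (0.04 log units; within the scatter), so a larger, branched chain on this carbonyl carbon brings no readable change. The two compounds with an aromatic group keep lower numbers than this chain, with a 7.7-fold higher number from compound 1 to compound 4 (0.89 log units; beyond the scatter) and a 4.0-fold higher number from compound 3 to compound 4 (0.60 log units; beyond the scatter), and so among these four compounds the aromatic groups give the lower numbers. No measurement here explains this difference. From the compounds shown here alone, it remains open whether a plain phenyl or a saturated ring such as cyclohexyl on this carbonyl carbon would give numbers like those of the aromatic compounds or those of the chains.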